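Swapping a Fluorinated Ring for a Methylated One

The compounds below may be only part of what the source reports. "The series", "measured", "known", "first", "only" and "open" are said of these compounds alone.

Of the compounds shown here, three sharing one core have been measured. Compound 1 `COCOc1ccccc1C[C@H]1C(=O)OC[C@@H]1Cc1ccccc1` gives 76000 nM in a functional assay on HL-60 cells (Homo sapiens) for cytotoxicity, read by WST assay, with a stated time of 48 h; on this read-out higher numbers stand for an effect only at larger amounts of compound and lower numbers for an effect already at smaller amounts. Compound 2 `CCCCOc1ccccc1C[C@H]1C(=O)OC[C@@H]1Cc1ccccc1` gives 20000 nM in this assay, and compound 3 `O=C1OC[C@H](Cc2ccccc2)[C@H]1Cc1ccccc1F` gives 72000 nM. Among these three numbers compound 3 stands second highest; its nearest step is a 1.1-fold lower number from compound 1 to compound 3 (0.02 log units; within the scatter), which lies within the scatter, while its furthest is a 3.6-fold higher number from compound 2 to compound 3 (0.56 log units; beyond the scatter), which lies beyond it. The change to compound 4 `Cc1cccc(C[C@H]2C(=O)OC[C@@H]2Cc2ccccc2)c1` is 3-methylphenyl in place of 2-fluorophenyl on a saturated chain carbon bound to a saturated ring carbon. For the measured compounds named here, no measured step exchanges a fluoro for a methyl, so none bears directly on this change; the closest precedents are the two steps that alter the substituent on the same ring, namely a 1.1-fold lower number from compound 1 to compound 3 (0.02 log units; within the scatter), within the scatter, and a 3.6-fold higher number from compound 2 to compound 3 (0.56 log units; beyond the scatter), a modest step. Substituent changes on this ring have so far moved the number by at most a modest amount, so for compound 4 a step of a 1.2-fold lower number from compound 3 to compound 4 (0.08 log units; within the scatter) is expected, within the scatter. Compound 4 is estimated at 60000 nM, with a range from 25000 nM to 150000 nM.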

Compound 4, half-maximal effective concentration: 53000 nM
Compound 4: the middle estimate sits 1.1-fold (0.05 log units) above what was measured; the range from low to high includes it.
By their numbers in this assay, from the lowest: compound 2; then compounds 4, 3 and 1 (each within the scatter of the next).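

In this assay, the exchange of 2-fluorophenyl for 3-methylphenyl gives a 1.4-fold lower number from compound 3 to compound 4 (0.13 log units; within the scatter), so this position tolerates a change of both the substituent and its place on the ring without a reading beyond the scatter. For the compounds shown here, this is the first measured step in which a carbon-only substituent replaces the fluoro, and it leaves compound 4 within the scatter of compound 3. Because the group and its place on the ring change together, the step cannot separate the two changes, and no available evidence explains the result.

The compounds shown leave open whether 2-methylphenyl or 3-fluorophenyl would read like compound 3 and compound 4. They also leave open whether a butoxy, an amine or a carboxylic acid on the 3-methylphenyl ring would move the number beyond the scatter.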